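Removing the Aryl Group from the Ring Amide Nitrogen

This account rests on a few compounds, and the source may have more. Where it says the series, first, only, none or still open, it means among the compounds named here.

Compound 1 `O=C1COc2ccc(-c3cnc4ccccc4c3)cc2N1c1ccccc1` gives > 40000 nM in a functional assay on A549 cells (Homo sapiens) for antiproliferative activity, read by MTT assay, with a stated time of 72 h (on this read-out higher numbers stand for weaker inhibition and lower numbers for stronger inhibition), which is a limit of the assay rather than a number. Compound 2 `O=C1COc2ccc(-c3cnc(Cl)c(NS(=O)(=O)c4ccc(F)cc4)c3)cc2N1c1ccc(F)cc1` gives 22300 nM. Compound 3 `COc1ncc(-c2ccc3c(c2)N(c2ccc(F)cc2)C(=O)CO3)cc1NS(=O)(=O)c1ccc(F)cc1` gives 6500 nM.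

Compound 3 holds the lowest number of the two measured values, with compound 2 set apart by a 3.4-fold lower number from compound 2 to compound 3 (0.54 log units; beyond the scatter). Compound 4 `COc1ncc(-c2ccc3c(c2)NC(=O)CO3)cc1NS(=O)(=O)c1ccc(F)cc1` differs from compound 3 by hydrogen in place of 4-fluorophenyl on an amide-type nitrogen in a ring. Among the compounds with values here, no measured step touches this nitrogen: the only step, a 3.4-fold lower number from compound 2 to compound 3 (0.54 log units; beyond the scatter), alters another ring. Compound 1 keeps an aromatic ring on that nitrogen yet reached only a limit, and it differs from compound 3 elsewhere too. The expected step of a 2.3-fold higher number from compound 3 to compound 4 (0.36 log units; beyond the scatter) is therefore uncertain, leaning toward a higher number. Compound 4 is estimated at 15000 nM, between 3000 nM and 60000 nM.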

Compound 4, half-maximal inhibitory concentration: 8070 nM
The estimate for compound 4 lay 1.9-fold (0.27 log units) above the measured number, within the range that was stated.
By their numbers in this assay, from the lowest: compounds 3 and 4 (each within the scatter of the next); then compound 2. At a limit, above all of these: compound 1.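

Putting hydrogen in place of 4-fluorophenyl on the amide-type nitrogen gives a 1.2-fold higher number from compound 3 to compound 4 (0.09 log units; within the scatter) in this assay. With the methoxy-bearing core, then, this whole aromatic ring can be removed without a change beyond the scatter, so this pair shows no need for it on this read-out. Nothing measured here explains this result. On these data alone, what remains open is how a methyl group or a longer chain ending in an amine on this nitrogen would behave. Whether the ring can also be removed from the chloro-bearing compound 2 is open too.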